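This account rests on a few compounds, and the source may have more. Where it says the series, first, only, none or still open, it means among the compounds named here.

Among the compounds with values here, compound 3, `Cc1cc(NC(=O)Nc2ccc(OC(F)(F)F)cc2)c2ccccc2n1`, is the one member of this small set for which an ADME assay on BJ cells (Homo sapiens) for cytotoxicity, with a stated time of 72 h (a lower number here means that less compound is needed, a higher number that more compound is needed for the effect), reports a number: compound 3 gives 25000 nM. Compound 1, `COc1ccc(NC(=O)Nc2cc(C)nc3ccccc23)cc1`, reaches only the limit of this assay, giving > 25000 nM. Compound 2, `Cc1cc(NC(=O)Nc2ccc(O)cc2)c2ccccc2n1`, likewise stops at that limit, giving > 25000 nM. The steps among the three therefore carry little: a number no higher from compound 1 to compound 3 (the limit leaves the size open) and a number no higher from compound 2 to compound 3 (the limit leaves the size open), while a step that the two limits leave unreadable from compound 1 to compound 2. the limit of > 25000 nM in this assay, at which 2 of the 3 values shown sit, marks the ceiling at which two of the three results sit.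

Compound 4, `Cc1cc(NC(=O)Nc2ccc(C(F)(F)F)cc2)c2ccccc2n1`, has not yet been measured in this assay. It differs from compound 3 by trifluoromethyl in place of trifluoromethoxy on an aromatic carbon. Within the data shown here, none of the measured steps touches this change directly: each of them alters what sits on the oxygen of an aromatic ring, whereas here the oxygen itself departs and only the trifluoromethyl remains on the aromatic carbon. With no readable step of any size among the three measured compounds, no movement beyond the scatter is expected, so the step of no change at the digits printed from compound 3 to compound 4 (within the scatter) is estimated to stay within the usual spread. Compound 4 is accordingly expected to give about 25000 nM, within 12000 nM to 50000 nM, with a real chance that this assay again reports only its limit.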

Compound 4, half-maximal effective concentration in the BJ assay: > 25000 nM
Compound 4: no number, only a limit; the forecaster's own chance of this, stated with the estimate: 50%; the middle value lies on the limit itself.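

Within the data shown here, in the BJ assay, trifluoromethyl in place of trifluoromethoxy on this aromatic carbon gives a number no lower from compound 3 to compound 4 (the limit leaves the size open), so the only number in the set is joined by one more limit, and the steps to compound 4 from compound 1 and from compound 2 cannot be read: the limit of > 25000 nM in the BJ assay, at which 3 of the 4 values shown sit. In a physicochemical assay for solubility, at pH 7.4 (on this read-out higher numbers stand for higher solubility and lower numbers for lower solubility), compound 3 gives 300 nM and compound 4 gives 100 nM, which brings a second read-out to this position. Solubility is thus where this change, which the earlier compounds did not touch, first has a readable size, one that lies beyond the scatter: the measured solubility of compound 3, 300 nM, and of compound 4, 100 nM, a 3.0-fold lower number (0.48 log units; beyond the scatter).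

The compounds shown leave open how an amine or a carboxylic acid on this aromatic carbon would read in the BJ assay and in the physicochemical assay, and whether any group here would bring a number clear of the limit. They also leave open whether the step in solubility between trifluoromethoxy and trifluoromethyl would hold on any core other than the shared one.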